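The source may report more compounds than this note shows. Statements on the series, on what has been measured and on what is new or still open speak of the compounds shown alone.

Measured in an in vivo ADME assay on the whole organism for pharmacokinetics, with Canis familiaris (Canis lupus familiaris) as the target; a higher number here means that more of the compound sits outside the plasma, a lower number that more of the compound stays in the plasma:
- compound 1 `Nc1noc2ccc(-n3nc(C(F)(F)F)c4c3C(=O)N(c3ccc(-c5ccccc5CN5CCCC5)cc3F)CC4)cc12`: 4.8 L/kg
- compound 2 `CN(C)Cc1ccccc1-c1ccc(N2CCc3c(C(F)(F)F)nn(-c4ccc5onc(N)c5c4)c3C2=O)c(F)c1`: 8.8 L/kg

Only these two compounds have been measured, and their values lie within the scatter of each other, so compound 2 has no separate standing on these numbers.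

The next structure is compound 3 `Nc1noc2ccc(-n3nc(C(F)(F)F)c4c3C(=O)N(c3ccc(-c5ccccc5CN5CC[C@@H](O)C5)cc3F)CC4)cc12`. The change is 3-hydroxypyrrolidin-1-yl in place of dimethylamino on a saturated chain carbon bound to an aromatic carbon.

For the measured compounds named here, one measured step bears on it: a 1.8-fold higher number from compound 1 to compound 2 (0.26 log units; within the scatter), which exchanges pyrrolidin-1-yl for dimethylamino at that same place. Going by the values given here, no measured compound carries 3-hydroxypyrrolidin-1-yl, so the data leave its contribution open. The closest measured structure is compound 1 at 4.8 L/kg, and compound 3 is expected to fall near that value, with a wide margin on either side.

The expected change, an estimate only, is a 2.5-fold lower number from compound 2 to compound 3 (0.40 log units; beyond the scatter). For compound 3 the estimated value is 3.5 L/kg, with an expected range of 1.6 L/kg to 7.5 L/kg.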

Compound 3, volume of distribution at steady state: 2.8 L/kg
Compound 3: the middle estimate sits 1.3-fold (0.10 log units) above what was measured; low and high end bracket the measured number.
By their numbers in this assay, from the lowest: compounds 3, 1 and 2 (each within the scatter of the next, the first and the last beyond it).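

In this assay, for the compounds shown here, the exchange of dimethylamino for 3-hydroxypyrrolidin-1-yl on a saturated chain carbon bound to an aromatic carbon gives the first step at this place that lies beyond the scatter (a 3.1-fold lower number from compound 2 to compound 3 (0.50 log units; beyond the scatter)), though a modest one. Hydroxy in place of hydrogen on a saturated ring carbon, read alone, stays within the scatter (a 1.7-fold lower number from compound 1 to compound 3 (0.23 log units; within the scatter)), so this single change cannot be separated from no change on these numbers, and the step beyond the scatter appears only between the two ends of the series, with compound 1 within the scatter of both. Nothing measured alongside these values bears on what lies behind the step.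

The compounds shown leave open whether the defined stereocentre of the 3-hydroxypyrrolidin-1-yl group matters, since its mirror-image form is not among them, and whether the hydrogen-bond donor of the hydroxy counts, which a methoxy on the same ring carbon would test. From the compounds shown here alone, how a larger amine such as piperidin-1-yl or morpholin-4-yl, or a carboxylic acid on the ring, would read at this place also remains open.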